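A few compounds are considered here, and "the series" means these few. Any claim that something is new, unique, unknown or untested is made for them only; others in the source may bear on it.

Measured so far in a functional assay on HeLa cells (Homo sapiens) for cytotoxicity, read by MTT assay, with a stated time of 3 days; a lower number here means a stronger inhibitor, a higher number a weaker inhibitor: compound 1 `Cc1ccc2nc(C)n(-n3c(N)cc(N)c(C#N)c3=O)c(=O)c2c1` gives 15000 nM; compound 2 `Cc1ccc2nc(C)n(NC(=O)c3sc(=S)n(-c4ccccc4)c3N)c(=O)c2c1` gives 35000 nM.

Compound 2 carries the highest of the two numbers in this assay; compound 1 sits lower by a gap beyond the usual scatter. Compound 3 `Cc1ccc2nc(C)n(NC(=O)c3sc(=S)n(Cc4ccccc4)c3N)c(=O)c2c1` is not yet measured and differs from compound 2 only by benzyl in place of phenyl on an aromatic nitrogen. For the measured compounds named here, no measured pair isolates this change, so the expected step from compound 2 to compound 3 is a 1.2-fold lower number from compound 2 to compound 3 (0.07 log units; within the scatter), with no clear direction beyond the scatter. Compound 3 is therefore estimated at 30000 nM, with a range from 12000 nM to 75000 nM.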

Compound 3, half-maximal inhibitory concentration: 26000 nM
Compound 3: the middle estimate sits 1.2-fold (0.06 log units) above what was measured; low and high end bracket the measured number.
By their numbers in this assay, from the lowest: compounds 1, 3 and 2 (each within the scatter of the next, the first and the last beyond it).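

In this assay, for the compounds shown here, benzyl in place of phenyl on the aromatic nitrogen gives a 1.3-fold lower number from compound 2 to compound 3 (0.13 log units; within the scatter) and is the first step that isolates a single place. This read-out does not separate the two groups at this position, and both compounds keep the amino group and the large group on the same ring. No measurement at hand accounts for the result.

Still open, going by these compounds, is whether a methyl group, a longer alkyl chain or a benzyl ring carrying a carboxylic acid on this nitrogen would move the number beyond the scatter. The compounds shown also do not test the neighbouring amino group on its own.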